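This account rests on a few compounds, and the source may have more. Where it says the series, first, only, none or still open, it means among the compounds named here.

Compound 1, `O=c1[nH]cnc2c1c(-c1ccoc1)cn2[C@@H]1O[C@H](CO)[C@@H](O)[C@H]1O`, and compound 2, `O=c1[nH]cnc2c1c(-c1ccsc1)cn2[C@@H]1O[C@H](CO)[C@@H](O)[C@H]1O`, carry a furan-3-yl and a thiophen-3-yl group, and both were tested in a functional assay on HeLa S3 cells (Homo sapiens) for antiproliferative activity, read by XTT assay, with a stated time of 72 h; a lower number here means a stronger inhibitor, a higher number a weaker inhibitor. In this assay compound 1 reached only the limit > 20000 nM. Compound 2 likewise reached only the limit > 20000 nM. The step that the two limits leave unreadable from compound 1 to compound 2 therefore cannot be read, and the limit of > 20000 nM in this assay, at which 2 of the 2 values shown sit, is all the two measurements offer. Compound 2 thus stands at the limit of this assay, without a number of its own.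

Compound 3, `O=c1[nH]cnc2c1c(-c1ccco1)cn2[C@@H]1O[C@H](CO)[C@@H](O)[C@H]1O`, has not yet been measured in this assay. It differs from compound 2 in one place: furan-2-yl in place of thiophen-3-yl on an aromatic carbon. Among the measured compounds shown here, the only measured step that bears on this change is a step that the two limits leave unreadable from compound 1 to compound 2, and the limits leave its size unknown. Nothing in the measured data points to a shift in either direction beyond the scatter. Compound 3 is therefore expected to sit at about 30000 nM, within a range from 15000 nM to 80000 nM. The step that the limit leaves unreadable from compound 2 to compound 3 implied by this estimate is expected to be essentially flat, with the limit most likely reached again.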

Compound 3, half-maximal inhibitory concentration: 5780 nM
The estimate for compound 3 lay 5.2-fold (0.72 log units) above the measured number, outside the stated range (below it).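

On an aromatic carbon of the five-membered aromatic ring in the shared core, the attached group now visibly matters: in this assay, furan-2-yl in place of thiophen-3-yl gives an at least 3.4-fold lower number from compound 2 to compound 3 (0.53 log units; beyond the scatter). Furan-2-yl in place of furan-3-yl gives an at least 3.4-fold lower number from compound 1 to compound 3 (0.53 log units; beyond the scatter), so two groups with the same ring and the same hetero atom, differing only in how the ring is attached, are now told apart in this read-out. Compound 3 is the only one of the three compounds with a number rather than a limit, and both steps give only a minimum size, with the true distance unknown: the limit of > 20000 nM in this assay, at which 2 of the 3 values shown sit.

The step between the two compounds at the limit cannot be read, so the compounds shown do not say whether the change of hetero atom alone has any effect at this carbon. From the compounds shown here alone, it also remains open whether thiophen-2-yl would behave like furan-2-yl, and whether a phenyl ring or an aminomethyl group on the same carbon would keep, improve or lose the activity of compound 3.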